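Triazole-bearing diterpenoid analogues tested for A549 cytotoxicity

This account rests on a few compounds, and the source may have more. Where it says the series, first, only, none or still open, it means among the compounds named here.

Compound 1 `COc1ccc(-c2cn(C[C@H]3c4c(ccc(OS(=O)(=O)c5ccc(C)cc5)c4C)[C@@H]4CC[C@@]5(C)C[C@]43CC5=O)nn2)cc1`: > 20000 nM
Compound 2 `Cc1ccc(S(=O)(=O)Oc2ccc3c(c2C)[C@H](Cn2cc(-c4ccc(Br)cc4)nn2)[C@@]24CC(=O)[C@@](C)(CC[C@@H]32)C4)cc1`: > 20000 nM
Compound 3 `C=C1C(=O)[C@]23C[C@@]1(O)CC[C@H]2c1ccc(O)c(C)c1[C@@H]3Cn1cc(-c2ccc(OC)cc2)nn1`: 1250 nM

In a functional assay on A549 cells (Homo sapiens) for cytotoxicity, read by MTT assay, with a stated time of 4 days (a lower number here means a stronger inhibitor, a higher number a weaker inhibitor), compound 1 reaches only a limit of the assay, > 20000 nM. Compound 2 likewise gives a limit, > 20000 nM. Their difference is bromo in place of methoxy on an aromatic carbon, and the step that the two limits leave unreadable from compound 1 to compound 2 cannot be sized; this rests on (the limit of > 20000 nM in this assay, at which 2 of the 3 values shown sit). Compound 3 gives a number in this assay, 1250 nM; how its core differs from that of compound 1 is not broken down here.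

Compound 4 `C=C1C(=O)[C@]23C[C@@]1(O)CC[C@H]2c1ccc(O)c(C)c1[C@@H]3Cn1cc(-c2ccc(Br)cc2)nn1` is not yet measured. It differs from compound 3 by bromo in place of methoxy on an aromatic carbon, the same kind of change as from compound 1 to compound 2, at the same place. Since that earlier step is unreadable, the expected step of a 1.2-fold higher number from compound 3 to compound 4 (0.08 log units; within the scatter) is taken as small and uncertain. Compound 4 is expected to give about 1500 nM in this assay, between 500 nM and 5000 nM.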

Compound 4, half-maximal inhibitory concentration: 1140 nM
Compound 4: middle estimate off by 1.3-fold (0.12 log units), on the high side, and the stated range covers the measured number.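

In this assay, the change from 4-methoxyphenyl to 4-bromophenyl on the core of compound 3 gives a 1.1-fold lower number from compound 3 to compound 4 (0.04 log units; within the scatter). On the core of compound 1 the same change cannot be read, because compound 1 and compound 2 both stand at a limit rather than at a number: the limit of > 20000 nM in this assay, at which 2 of the 4 values shown sit. The new step therefore shows what this change does on one core only, and it does not show that the two cores respond alike.

The compounds shown leave open whether an amine or a carboxylic acid in place of the bromo would alter the number in this assay. They also leave open which part of the core difference separates compound 3 from compound 1.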